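The source may report more compounds than this note shows. Statements on the series, on what has been measured and on what is new or still open speak of the compounds shown alone.

Measured so far:
compound 1, `O=C(NC1CCCCC1)c1ccccc1OCc1ccccc1`: 43400 nM
compound 2, `O=C(Nc1cccnc1)c1ccccc1OCc1ccccc1C(F)(F)F`: 2100 nM
compound 3, `N#Cc1ccccc1COc1ccccc1C(=O)Nc1cccnc1`: 31800 nM

In an assay on lysate for inhibition of phosphatidylcholine:ceramide cholinephosphotransferase 2 (Homo sapiens), read by HPLC, with stated times of 30 min and 2 h (a higher number here means a weaker inhibitor, a lower number a stronger inhibitor), compound 3 stands second highest of the three numbers; its nearest neighbour is compound 1, within the scatter, and its furthest is compound 2, well beyond it. Compound 4 is `Cc1ccc(Cl)cc1COc1ccccc1C(=O)Nc1cccnc1`. The change from compound 3 to compound 4 is 5-chloro-2-methylphenyl in place of 2-cyanophenyl on a saturated chain carbon bound to an oxygen on an aromatic ring. Among the measured compounds shown here, the one measured step that bears on this place is a 15-fold higher number from compound 2 to compound 3 (1.18 log units; beyond the scatter), which shows that the group on this saturated chain carbon can shift the number a long way in this assay. For the measured compounds named here, compound 4 carries neither the cyano of compound 3 nor the trifluoromethyl of compound 2, so no measured step matches it directly, and the direction is uncertain. For compound 4 the expected step is a 6.4-fold lower number from compound 3 to compound 4 (0.80 log units; beyond the scatter), downward, leaning on the fact that compound 2 gives 2100 nM with a different group at the same place. The estimate for compound 4 in this assay is 5000 nM, in a range of 1500 nM to 18000 nM.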

Compound 4, half-maximal inhibitory concentration: 1100 nM
For compound 4 the middle estimate is 4.5-fold (0.66 log units) above the measured one; measured number outside the range, below it.
By their numbers in this assay, from the lowest: compounds 4 and 2 (each within the scatter of the next); then compounds 3 and 1 (each within the scatter of the next).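

In this assay, a 29-fold lower number from compound 3 to compound 4 (1.46 log units; beyond the scatter) shows that replacing 2-cyanophenyl with 5-chloro-2-methylphenyl on this saturated chain carbon can recover a low number without trifluoromethyl. Compound 4 gives 1100 nM and compound 2 gives 2100 nM, values within the scatter of each other, so among the groups shown at this place, a low number is not confined to the trifluoromethyl of compound 2, while the nitrile of compound 3 goes with a much higher number. No supporting measurement explains this change.

On these data alone, it remains open whether the chloro, the methyl or the two together account for the step from the nitrile, and whether an amine or a methoxy in place of the chloro would keep the number low. Compound 1 differs from the other compounds in more than one place, so the contribution of the group on the amide nitrogen also remains unresolved.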